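The compounds below may be only part of what the source reports. "The series", "measured", "known", "first", "only" and "open" are said of these compounds alone.

In an ADME assay on BJ cells (Homo sapiens) for cytotoxicity, read by luminescence, with a stated time of 72 h (a lower number here means that less compound is needed, a higher number that more compound is needed for the effect), compound 3 (`CCOC(=O)c1c(-c2cccc(OC)c2)[nH]c2cc(OC)c(OC)cc2c1=O`) gives > 21500 nM, a limit and not a number. Compound 2 (`CCOC(=O)c1c(-c2cccc(-c3ccccc3)c2)[nH]c2cc(OC)c(OC)cc2c1=O`) gives > 21500 nM, also a limit. Compound 1 (`CCOC(=O)c1c(-c2cccc(Oc3ccccc3)c2)[nH]c2cc(OC)ccc2c1=O`), which already carries the phenoxy, gives > 21500 nM, again a limit. Within the data shown here, the series so far therefore stands at the limit of > 21500 nM in this assay, at which 3 of the 3 values shown sit.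

Compound 4 (`CCOC(=O)c1c(-c2cccc(Oc3ccccc3)c2)[nH]c2cc(OC)c(OC)cc2c1=O`) follows from compound 3 by phenyl in place of methyl on an oxygen on an aromatic ring, methoxy to phenoxy. Among the measured compounds shown here, the only measured step of a related kind is a step that the two limits leave unreadable from compound 2 to compound 3, with methoxy in place of phenyl on an aromatic carbon, so it gives no size to carry over. Expected in this assay is a number no higher from compound 3 to compound 4 (the limit leaves the size open), nothing beyond the scatter and in neither direction. For compound 4 the estimate is 21500 nM, with an expected range of 9000 nM to 40000 nM.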

Compound 4, half-maximal effective concentration: > 21500 nM
Compound 4: no number, only a limit (the forecaster's own chance of this, stated with the estimate: 85%); the middle value sits exactly at the limit.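

In this assay compound 4 gives > 21500 nM, a limit, so the steps to it from compound 1, compound 2 and compound 3 cannot be read. The compounds shown leave open whether any change among them alters the read-out at all.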